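Removing the Fluorine from Compound 3: An Expected Outcome

The compounds below may be only part of what the source reports. "The series", "measured", "known", "first", "only" and "open" are said of these compounds alone.

Measured compounds and their values in a functional assay on Vero cells (Chlorocebus sabaeus) for inhibition; a higher number here means a weaker inhibitor, a lower number a stronger inhibitor:
compound 1 `Nc1ncnc2c1ncn2[C@@H]1O[C@@H](CO)C=C1F` gives > 100000 nM
compound 2 `Nc1nc(F)nc2c1ncn2[C@@H]1O[C@@H](CO)C=C1F` gives > 100000 nM
compound 3 `Nc1nc(F)nc2c1ncn2[C@H]1O[C@@H](CO)C=C1F` gives 173000 nM

The value of compound 1 in this assay is a limit of the assay and not a number. The value of compound 2 in this assay is likewise a limit. Among the compounds with values here, compound 3 is the only compound of the three with a measured number, and it stands as a weak inhibitor. The step that the two limits leave unreadable from compound 1 to compound 2 cannot be read because of the limit of > 100000 nM in this assay, at which 2 of the 3 values shown sit. The step that the limit leaves unreadable from compound 2 to compound 3 is also unreadable, and it rests on (the fact that compounds 2 and 3 differ only in the configuration as drawn).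

Compound 4 `Nc1ncnc2c1ncn2[C@H]1O[C@@H](CO)C=C1F` is now to be measured in this assay. It differs from compound 3 by hydrogen in place of fluoro on an aromatic carbon. Within the data shown here, the only measured step with the same kind of change, in the opposite direction, is a step that the two limits leave unreadable from compound 1 to compound 2, and that step gives no readable size. Among the measured compounds shown here, no measured step therefore supports a change beyond the scatter, and the estimate for the step of a 1.0-fold lower number from compound 3 to compound 4 (0.01 log units; within the scatter) is that it stays within the scatter. Compound 4 is estimated at 170000 nM, with a range from 60000 nM to 500000 nM, and it may well come back as a limit rather than a number.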

Compound 4, half-maximal inhibitory concentration: > 100000 nM
Compound 4: a limit, no number; the forecaster's own chance of this, stated with the estimate: 60%; the middle value is on the limit's open side.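

In this assay compound 4 gives > 100000 nM as a limit of the assay and not a number. Neither its step from compound 3 nor its step from compound 1 can be read, and this rests on: the limit of > 100000 nM in this assay, at which 3 of the 4 values shown sit. The compounds shown leave open how far the fluoro on the aromatic carbon or the configuration at the saturated ring carbon shifts the value.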